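The source may hold more compounds than are shown below. What is called first, only, known or untested is meant among the compounds shown, and "the series" means these compounds.

Of the compounds shown here, three built on one shared core have been measured in a functional assay on isolated protein for inhibition of Glucose-dependent insulinotropic receptor (Rattus norvegicus), read by HTRF and cAMP accumulation; on this read-out higher numbers stand for an effect only at larger amounts of compound and lower numbers for an effect already at smaller amounts. Compound 1 `Cc1nc(S(C)(=O)=O)ccc1Oc1ncnc(OC2CCN(C(=O)OC(C)(C)C(F)(F)F)CC2)c1F` gives 47.2 nM, the second highest of the three numbers. Compound 3 `Cc1nc(S(C)(=O)=O)ccc1Oc1ncnc(OC2CCN(C(=O)SC(C)C)CC2)c1F` gives 41.3 nM; the step between them is a 1.1-fold lower number from compound 1 to compound 3 (0.06 log units; within the scatter). Compound 2 `Cc1nc(S(C)(=O)=O)ccc1Oc1ncnc(OC2CCN(C(=O)OC(C)F)CC2)c1F` gives 315 nM; here the step is a 6.7-fold higher number from compound 1 to compound 2 (0.82 log units; beyond the scatter). Compound 4 `Cc1nc(S(C)(=O)=O)ccc1Oc1ncnc(OC2CCN(C(=O)SC3(C)CC3)CC2)c1F` differs from compound 1 in one place: a group of 5 heavy atoms (4 carbon, 1 sulfur; one three-membered non-aromatic ring of carbon only) in place of a group of 8 heavy atoms (4 carbon, 1 oxygen, 3 fluorine; no ring), on a carbonyl carbon. Among the measured compounds shown here, the step that bears on this is the one to compound 3, where the same ethoxy group was replaced by isopropylsulfanyl and the number moved only within the scatter, so no step beyond the scatter is expected in this assay. Compound 4 is therefore estimated at 42 nM, with a range from 20 nM to 95 nM. This expectation corresponds to a step of a 1.1-fold lower number from compound 1 to compound 4 (0.05 log units; within the scatter).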

Compound 4, half-maximal effective concentration: 166 nM
The estimate for compound 4 lay 4.0-fold (0.60 log units) below the measured number; measured number outside the range, above it.
By their numbers in this assay, from the lowest: compounds 3 and 1 (each within the scatter of the next); then compounds 4 and 2 (each within the scatter of the next).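

Putting 1-methylcyclopropyl in place of isopropyl on the sulfur gives a 4.0-fold higher number from compound 3 to compound 4 (0.60 log units; beyond the scatter) and shows that this position responds to a small change in the group carried by the sulfur. Sulfur there therefore does not by itself keep the number of compound 1, as a 3.5-fold higher number from compound 1 to compound 4 (0.55 log units; beyond the scatter) shows. The step of a 1.9-fold lower number from compound 2 to compound 4 (0.28 log units; within the scatter) leaves compound 4 not separable from the 1-fluoroethyl compound.

The data shown give no reason for these shifts. Also open, on these data alone, is how an n-butyl chain or a dimethylamino group would read on the carbonyl carbon.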